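Oxazole-type ketones: a nitro-for-fluoro swap on compound 3

The compounds below may be only part of what the source reports. "The series", "measured", "known", "first", "only" and "open" are said of these compounds alone.

The series shares a ketone bearing a six-carbon chain to a phenyl ring; the variation sits in the fused heteroaromatic part. Compound 1 `O=C(CCCCCc1ccccc1)c1nc2ncccc2[nH]1` gives 1230 nM in an assay on HEK-293T cells for inhibition of diacylglycerol lipase-alpha (Homo sapiens), read by colorimetric assay; on this read-out lower numbers stand for stronger inhibition and higher numbers for weaker inhibition. Compound 2 `O=C(CCCCCc1ccccc1)c1nc2c(F)cccc2o1` gives 117 nM in this assay, and compound 3 `O=C(CCCCCc1ccccc1)c1nc2cc(F)ccc2o1` gives 1410 nM there. Compound 3 thus carries the highest number of the three; its value and that of compound 1 lie within the scatter of each other, whereas compound 2 stands beyond the scatter with the lower number.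

Compound 4 `O=C(CCCCCc1ccccc1)c1nc2cc([N+](=O)[O-])ccc2o1` differs from compound 3 by nitro in place of fluoro on an aromatic carbon. Among the compounds with values here, no measured pair shows this kind of change, so nothing in the data fixes its size or direction. The step from compound 3 to compound 4 is therefore expected to be small, a 1.1-fold higher number from compound 3 to compound 4 (0.03 log units; within the scatter), and not clearly beyond the scatter. Compound 4 is accordingly estimated at 1500 nM in this assay, with a range from 500 nM to 5000 nM.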

Compound 4, half-maximal inhibitory concentration: 891 nM
Estimate against measurement, compound 4: 1.7-fold (0.23 log units) above, and the stated range covers the measured number.
By their numbers in this assay, from the lowest: compound 2; then compounds 4, 1 and 3 (each within the scatter of the next).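

In this assay, within the data shown here, the swap gives a 1.6-fold lower number from compound 3 to compound 4 (0.20 log units; within the scatter) on this ring carbon, the first step with a single point of change. At this position, therefore, nitro and fluoro cannot be told apart within the scatter, even though they differ in heavy atoms and hydrogen-bond acceptors. This one pair gives no basis for a trend across substituents, and no supporting data bear on the reason for the result.

From the compounds shown here alone, whether an amine or a carboxylic acid on the same carbon would also stay within the scatter of compound 3 remains open. So does the outcome of placing nitro on the carbon that carries fluoro in compound 2, whose number is beyond the scatter of that of compound 3.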